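The compounds below may be only part of what the source reports. "The series", "measured", "known", "first", "only" and "open" are said of these compounds alone.

The three measured compounds share one core and differ only in the chain on it. Compound 1 `CC(C)(C)[Si](C)(C)O[C@H]1CCCO[C@@H]1CC=O` gives 21000 nM in a functional assay on MCF7S cells (Homo sapiens); on this read-out higher numbers stand for weaker inhibition of growth and lower numbers for stronger inhibition of growth. Compound 2 `CC(C)(C)[Si](C)(C)O[C@H]1CCCO[C@@H]1C/C=C/CO` gives 25000 nM in this assay, and compound 3 `COC(=O)/C=C/[C@H]1OCCC[C@@H]1O[Si](C)(C)C(C)(C)C` gives 24000 nM in this assay. Compound 3 stands second highest of the three numbers, though every step among them lies within the scatter: a 1.2-fold higher number from compound 1 to compound 2 (0.08 log units; within the scatter), a 1.1-fold higher number from compound 1 to compound 3 (0.06 log units; within the scatter) and a 1.0-fold lower number from compound 2 to compound 3 (0.02 log units; within the scatter).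

Compound 4 `COC(=O)/C=C\[C@H]1OCCC[C@@H]1O[Si](C)(C)C(C)(C)C` keeps every atom and bond of compound 3; (the two compounds have the same atoms and bonds and differ only in configuration as drawn: 1 of 3 stereo elements differ; a double bond is drawn E in compound 3 and Z in compound 4). Among the compounds with values here, no measured step here concerns a change of double-bond geometry, so none bears directly on it; the measured steps only show that the chain on this core has been altered in several ways without moving this assay beyond the scatter. On that basis no step beyond the scatter is expected in either direction, and compound 4 is estimated at 24000 nM, within 10000 nM to 55000 nM, which means an expected step of no change at the digits printed from compound 3 to compound 4 (within the scatter).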

Compound 4, concentration for 50% growth inhibition: 32000 nM
Estimate against measurement, compound 4: 1.3-fold (0.12 log units) below, and the stated range covers the measured number.
By their numbers in this assay, from the lowest: compounds 1, 3, 2 and 4 (each within the scatter of the next).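

Double-bond geometry in the 2-(methoxycarbonyl)ethenyl group is tested here for the first time, and in this assay the result is a 1.3-fold higher number from compound 3 to compound 4 (0.12 log units; within the scatter). The Z compound also stays within the scatter of the two compounds with other chains, with a 1.3-fold higher number from compound 2 to compound 4 (0.11 log units; within the scatter) and a 1.5-fold higher number from compound 1 to compound 4 (0.18 log units; within the scatter), so the change of geometry joins the changes of chain in not moving this read-out beyond the scatter. The first of these steps isolates geometry alone, and the basis for reading it so is this: the fact that compounds 3 and 4 differ only in the configuration as drawn.

As far as these compounds go, whether any change on this chain can move the read-out beyond the scatter stays open, for instance a carboxylic acid in place of the methyl ester or an amine at the chain end. From the compounds shown here alone, the silyl ether is common to all four compounds, so what it contributes to these values also remains unknown.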